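Tetrazolyl for hydrogen on the pyridyl amine of compound 1

The source may hold more compounds than are shown below. What is called first, only, known or untested is meant among the compounds shown, and "the series" means these compounds.

Compound 1 `FC(F)(F)c1cccc(-c2nc3cnc(Nc4ccccn4)cc3[nH]2)c1` is the parent of this series. In a physicochemical assay for solubility, using the shake flask method, in phosphate buffer, measured as kinetic solubility, with a stated time of 20 h, at pH 6.5 (a higher number here means a more soluble compound, a lower number a less soluble compound), compound 1 reaches only a limit, < 5000 nM, so its standing rests on that limit alone (the limit of < 5000 nM in this assay, at which 1 of the 2 values shown sits). Compound 2 `O=C(O)c1ccc(Nc2cc3[nH]c(-c4cccc(C(F)(F)F)c4)nc3cn2)nc1` carries carboxy in place of hydrogen on an aromatic carbon; in this assay compound 2 gives 6000 nM. Within the data shown here, the one measured step, an at least 1.2-fold higher number from compound 1 to compound 2 (0.07 log units; that floor lies within the scatter), is the sole guide here.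

Compound 3 `FC(F)(F)c1cccc(-c2nc3cnc(Nc4cc(-c5nnn[nH]5)ccn4)cc3[nH]2)c1` differs from compound 1 by 1H-tetrazol-5-yl in place of hydrogen on an aromatic carbon. The change resembles the step to compound 2 in that a hydrogen on an aromatic carbon gives way to a small group with 1 hydrogen-bond donor and several acceptors, so an upward step of similar size, beyond the limit of compound 1, is expected, an at least 1.2-fold higher number from compound 1 to compound 3 (0.07 log units; that floor lies within the scatter). Compound 3 is therefore estimated at 6000 nM in this assay, with a range from 3000 nM to 15000 nM.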

Compound 3, solubility: < 5000 nM
Compound 3: only a limit was reported; the forecaster's own chance of this, stated with the estimate: 40%; at least 1.2-fold (0.07 log units) between middle value and limit.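

In this assay compound 3 gives only a limit, < 5000 nM. Among these compounds, compound 1 also stands at a limit, so no step from compound 1 to compound 3 can be read. Still open, as far as these compounds go, is whether 1H-tetrazol-5-yl in place of hydrogen moves this read-out in either direction.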